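This account rests on a few compounds, and the source may have more. Where it says the series, first, only, none or still open, it means among the compounds named here.

Measured so far:
Compound 1, `COc1cc2c(cc1OC)C(CC(=O)Nc1ccccc1)CC2`: in a functional assay on the whole organism (strain Wistar) for inhibition, with Rattus norvegicus as the target, read by paw edema, with a stated time of 24 h, at a dose of 100 mg/kg (a higher number here means more inhibition at the dose given (going by the name of the read-out), a lower number less inhibition), compound 1 gives 30%.
Compound 2, `COc1cc2c(cc1OC)C(CC(=O)Nc1ccc(C)cc1)CC2`: in this assay compound 2 gives 30%.

Within the data shown here, compound 2 stands level with compound 1 on these numbers; the single step in the set, no change at the digits printed from compound 1 to compound 2 (within the scatter), shows that exchanging a hydrogen for a methyl on the aromatic carbon of the anilide ring left the inhibition where it was.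

Compound 3, `COc1cc2c(cc1OC)C(CC(=O)Nc1ccc([N+](=O)[O-])cc1)CC2`, has not been measured. It differs from compound 2 by nitro in place of methyl on an aromatic carbon.

Among the measured compounds shown here, only one measured step bears on this change, and it is the one at the same aromatic carbon, no change at the digits printed from compound 1 to compound 2 (within the scatter), which was flat within the scatter. For the measured compounds named here, no step with a nitro group, or with any group carrying hydrogen-bond acceptors at this carbon, has been measured, so the data give no direction for the nitro itself. Going by the values given here, on the one step available, the expectation for this assay is a step of about no change at the digits printed from compound 2 to compound 3 (within the scatter), that is, none beyond the scatter.

Compound 3 is therefore estimated at 30%, with a range from 15% to 45%.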

Compound 3, a percentage reported as inhibition, in the whole organism at one dose (the size of the read-out at that dose, not a potency): 43.3%
For compound 3 the middle estimate is 13.3 percentage points below the measured one, within the range that was stated.
By their numbers in this assay, from the lowest: compounds 1 and 2 (each within the scatter of the next); then compound 3.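

In this assay the aromatic carbon para to a large group is not indifferent to substitution: methyl in place of hydrogen gave no change at the digits printed from compound 1 to compound 2 (within the scatter) while nitro in place of methyl gives a number 13.3 percentage points higher from compound 2 to compound 3 (beyond the scatter) and nitro in place of hydrogen gives a number 13.3 percentage points higher from compound 1 to compound 3 (beyond the scatter) as its counterpart. Among these compounds, both new steps are modest and end at the same compound, so the only change beyond the scatter at this carbon rests on nitro alone, with hydrogen and methyl level with each other. Nothing on hand accounts for this rise, and it stands as an observation without an explanation.

On these data alone, whether the rise is particular to nitro or would also appear with another group at this carbon, such as a nitrile, a carboxylic acid, an amine or a longer chain, remains open. Also open, as far as these compounds go, is whether nitro on another aromatic carbon of the same ring would give a similar reading, and whether the rise would hold at other doses or times.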